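Swapping chloro for trifluoromethyl on a second core

The compounds below may be only part of what the source reports. "The series", "measured", "known", "first", "only" and "open" are said of these compounds alone.

Compound 1 `O=C(/C=C\Nc1ccc(Cl)cc1)c1cn(-c2ccccc2)nc1-c1ccc(Cl)cc1`, compound 2 `O=C(/C=C\Nc1ccc(C(F)(F)F)cc1)c1cn(-c2ccccc2)nc1-c1ccc(Cl)cc1`, compound 3 `COc1ccc(-c2nn(-c3ccccc3)cc2C(=O)/C=C\Nc2ccc(Cl)cc2)cc1` and compound 4 `COc1ccc(-c2nn(-c3ccccc3)cc2C(=O)/C=C\Nc2ccc(C(F)(F)F)cc2)cc1` share one scaffold and differ only in single groups on their outer rings. They were tested in an ADME assay on HaCaT cells (Homo sapiens) for antiproliferative activity, read by MTT assay, with a stated time of 48 h; on this read-out lower numbers stand for stronger inhibition and higher numbers for weaker inhibition. In this assay compound 1 gives 23400 nM. Compound 2 gives only a limit, not a number, in this assay, > 50000 nM, and that is the limit of > 50000 nM in this assay, at which 1 of the 3 values shown sits. Compound 3 gives 20900 nM in this assay.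

The difference between compound 1 and compound 2 is trifluoromethyl in place of chloro on an aromatic carbon. This change made an at least 2.1-fold higher number from compound 1 to compound 2 (0.32 log units; beyond the scatter). The cores of compound 1 and compound 3 differ by methoxy in place of chloro on an aromatic carbon, and that change made a 1.1-fold lower number from compound 1 to compound 3 (0.05 log units; within the scatter).

Compound 4 carries the same kind of change against compound 3 that compound 2 carries against compound 1, namely (trifluoromethyl in place of chloro on an aromatic carbon). The place of the change is described in the same words in both pairs, so it is the same change set on a different core. Since the earlier step gave an at least 2.1-fold higher number from compound 1 to compound 2 (0.32 log units; beyond the scatter), a step of similar direction and at least similar size is expected for the new pair, estimated as a 2.2-fold higher number from compound 3 to compound 4 (0.33 log units; beyond the scatter). On that basis compound 4 is estimated to give 45000 nM in this assay, with an expected range from 25000 nM to 90000 nM, and it may well return only a limit.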

Compound 4, half-maximal inhibitory concentration: > 50000 nM
Compound 4 gave a limit, no number (the forecaster's own chance of this, stated with the estimate: 50%); middle value at least 1.1-fold (0.04 log units) away from the limit.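

Carrying trifluoromethyl in place of chloro onto the core of compound 3 gave an at least 2.3-fold higher number from compound 3 to compound 4 (0.37 log units; beyond the scatter) in this assay, so the change pushes the number the same way on both cores shown, although these results do not say why. Set side by side, the two steps agree in direction, but their sizes cannot be compared with any confidence: the same change on two cores in this assay, an at least 2.1-fold higher number (0.32 log units; beyond the scatter) from compound 1 to compound 2 and an at least 2.3-fold higher number (0.37 log units; beyond the scatter) from compound 3 to compound 4; the limit leaves it open whether they differ Compound 4 gives > 50000 nM, which is a limit of the assay and not a number, and compound 2 also stands at a limit, so the true size of the change stays unknown on both cores and the step joining those two compounds cannot be read: the limit of > 50000 nM in this assay, at which 2 of the 4 values shown sit.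

Among the compounds shown here, with only two cores and one swap on view, it remains open whether the same direction would hold on a core carrying a different group in place of the methoxy or chloro on the other outer ring. On these data alone, it is also open how a group such as an amine, a carboxylic acid or a longer chain in place of chloro, on the same aromatic carbon, would compare with the chloro compounds in this assay.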